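Replacing 4-nitrophenyl: what cells may tolerate

A few compounds are considered here, and "the series" means these few. Any claim that something is new, unique, unknown or untested is made for them only; others in the source may bear on it.

- Compound 1 `CC(C)(C)NC(=O)COC(=O)c1ccc([N+](=O)[O-])o1` gives > 100000 nM as a limit
- Compound 2 `CC(C)(C)N(Cc1ccc([N+](=O)[O-])cc1)C(=O)COC(=O)c1ccc([N+](=O)[O-])o1` gives > 100000 nM as a limit
- Compound 3 `CC(C)(C)N(Cc1ccc(OCc2ccccc2)cc1)C(=O)COC(=O)c1ccc([N+](=O)[O-])o1` is reported as "not active" (no number reported) with no number

In an ADME assay on HEK-293T cells (Homo sapiens) for cytotoxicity, read by MTT assay, with a stated time of 3 days (a higher number here means that more compound is tolerated, a lower number that less compound is tolerated), compound 2 stands at > 100000 nM as a limit and not a number. Among the compounds with values here, the closest guide in these data is the limit of > 100000 nM in this assay, at which 2 of the 3 values shown sit, and no measured pair shows a single change. Compound 4 `CC(C)(C)N(Cc1ccccc1C(F)(F)F)C(=O)COC(=O)c1ccc([N+](=O)[O-])o1` carries 2-(trifluoromethyl)phenyl in place of 4-nitrophenyl on a saturated chain carbon bound to an amide-type nitrogen. In this assay no change beyond the usual scatter is expected. The estimated change is a number no higher from compound 2 to compound 4 (the limit leaves the size open) in size, with no direction expected. For compound 4 the estimated value is 100000 nM (range 40000 nM to 150000 nM).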

Compound 4, half-maximal cytotoxic concentration: 65000 nM
Compound 4: the middle estimate sits 1.5-fold (0.19 log units) above what was measured; measured number inside the range.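

In this assay, within the data shown here, compound 4 gives 65000 nM as a real number, the first for any group on this saturated chain carbon bound to an amide-type nitrogen. Putting 2-(trifluoromethyl)phenyl in place of 4-nitrophenyl gives an at least 1.5-fold lower number from compound 2 to compound 4 (0.18 log units; that floor lies within the scatter) and so is not shown to matter. Compound 2 has only a limit, which leaves the true size of this step open.

Still open, from the compounds shown here alone, is what a phenyl ring carrying an amine or a carboxylic acid would give at this place. Also open, going by these compounds, is whether any group here can bring the number clearly down.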